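Replacing 4-hydroxyphenyl with 2,4-dichlorophenyl in two measured compounds

This account rests on a few compounds, and the source may have more. Where it says the series, first, only, none or still open, it means among the compounds named here.

Compound 1 `O=C(Cc1csc2nc(-c3ccc(Br)cc3)cn12)N/N=C/c1ccccc1`: 14500 nM
Compound 2 `O=C(Cc1csc2nc(-c3ccc(Br)cc3)cn12)N/N=C/c1ccc(O)cc1`: 22400 nM

In a functional assay on DU-145 cells (Homo sapiens) for inhibition, read by sulforhodamine B assay, with a stated time of 48 h (on this read-out lower numbers stand for stronger inhibition of growth and higher numbers for weaker inhibition of growth), compound 2 gives 22400 nM. Among the measured compounds shown here, the only other measured value, 14500 nM from compound 1, lies within the scatter of it, so the two compounds cannot be ranked. Compound 3 `O=C(Cc1csc2nc(-c3ccc(Br)cc3)cn12)N/N=C/c1ccc(Cl)cc1Cl` differs from compound 2 by one change: 2,4-dichlorophenyl in place of 4-hydroxyphenyl on a carbon with a double bond to nitrogen. For the measured compounds named here, only one measured step bears on this change, and only in part: a 1.5-fold higher number from compound 1 to compound 2 (0.19 log units; within the scatter). Going by the values given here, that step concerns the hydroxy group that compound 3 also lacks, but no measured compound carries 2,4-dichlorophenyl, so the data say little about the chlorines. No step beyond the scatter is therefore expected in this assay, and any shift would more likely be towards a lower number. The estimate for compound 3 means an expected 1.6-fold lower number from compound 2 to compound 3 (0.20 log units; within the scatter). Compound 3 is expected to give 14000 nM, with an estimated range of 5000 nM to 38000 nM.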

Compound 3, concentration for 50% growth inhibition: 26300 nM
For compound 3 the middle estimate is 1.9-fold (0.27 log units) below the measured one; the range from low to high includes it.
By their numbers in this assay, from the lowest: compounds 1, 2 and 3 (each within the scatter of the next).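

In this assay, 2,4-dichlorophenyl in place of 4-hydroxyphenyl brings a 1.2-fold higher number from compound 2 to compound 3 (0.07 log units; within the scatter), and in place of phenyl it brings a 1.8-fold higher number from compound 1 to compound 3 (0.26 log units; within the scatter). The earlier pair covered only a hydroxy group on the ring, whereas these steps add two chlorines and still leave phenyl, 4-hydroxyphenyl and 2,4-dichlorophenyl unseparated on the carbon with a double bond to nitrogen, so compounds 1, 2 and 3 cannot be ranked. Nothing available accounts for this lack of separation.

Going by these compounds, whether an amine, a carboxylic acid or a longer chain at this place would move the number beyond the scatter remains open. Also open, on these data alone, is whether a change elsewhere in the shared core would do so.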